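The compounds below may be only part of what the source reports. "The series", "measured", "known", "first", "only" and "open" are said of these compounds alone.

Measured so far:
Compound 1, `COc1ccc(-n2c(=O)n(Cc3cc4cc(Cl)ccc4n3CCCC#N)c3cnccc32)cc1`, in an ADME assay on HeLa cells (Homo sapiens) for cytotoxicity, read by ATP content, with a stated time of 3 days (on this read-out higher numbers stand for lower toxicity in this test and lower numbers for higher toxicity in this test), gives > 50000 nM.
Compound 2, `O=c1n(Cc2cc3ccncc3n2CCCCO)c2cnccc2n1C1CC1`, in this assay gives > 100000 nM.

For compound 1 the reading is a limit of the assay, (the limit of > 50000 nM in this assay, at which 1 of the 2 values shown sits), not a measured number. For compound 2 the reading is likewise a limit, (the limit of > 100000 nM in this assay, at which 1 of the 2 values shown sits). Where compound 1 stands among the two values can therefore only be said loosely: both compounds sit at limits, so neither can be ranked against the other, and both show low toxicity toward these cells.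

Compound 3, `N#CCCCn1c(Cn2c(=O)n(C3CC3)c3ccncc32)cc2cc(Cl)ccc21`, is the compound still to be measured. It differs from compound 1 in one place: cyclopropyl in place of 4-methoxyphenyl on an aromatic nitrogen. The same cyclopropyl group is present in compound 2. Within the data shown here, no step between two measured compounds is known here, so the size of the change cannot be read from the data; with both measured compounds sitting at limits, no shift beyond the scatter is expected in this assay. For compound 3 a value of 80000 nM is estimated, with a range from 30000 nM to 200000 nM. This estimate means an expected step that the limit leaves unreadable from compound 1 to compound 3, and the result is expected most likely to be reported again as a limit.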

Compound 3, half-maximal cytotoxic concentration: > 50000 nM
Compound 3: no number, only a limit (the forecaster's own chance of this, stated with the estimate: 75%); the middle value lies beyond the limit too.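

In this assay compound 3 gives > 50000 nM, which is a limit of the assay and not a number. Compound 1 also sits at a limit, so no step can be read between compound 1 and compound 3. The compounds shown leave open whether cyclopropyl in place of 4-methoxyphenyl changes toxicity toward these cells at all.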